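The source may report more compounds than this note shows. Statements on the series, on what has been measured and on what is new or still open speak of the compounds shown alone.

Measured so far in a functional assay on Jurkat cells (Homo sapiens) for inhibition, read by CCK-8 assay, with a stated time of 48 h; a higher number here means a weaker inhibitor of growth, a lower number a stronger inhibitor of growth:
compound 1, `Cc1ccccc1Nc1nc(Nc2ccccc2)ncc1Cl`, gives > 100000 nM.
compound 2, `CCN1CCN(c2ccc(Nc3ncc(Cl)c(Nc4ccccc4C)n3)cc2)CC1`, gives 2060 nM.
compound 3, `CN1CCN(c2ccc(Nc3ncc(Cl)c(NCc4ccc(F)cc4)n3)nc2)CC1`, gives > 100000 nM.

For compound 3 the value is a limit of the assay, not a number, so compound 3 stands at the edge of what this assay resolves; see (the limit of > 100000 nM in this assay, at which 2 of the 3 values shown sit). For compound 1 the value is likewise only a limit. Among the measured compounds shown here, the single step between compounds differing in one place is an at least 48-fold lower number from compound 1 to compound 2 (1.68 log units; beyond the scatter), and it concerns the aromatic carbon that carries the piperazine, not the nitrogen changed here.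

Compound 4 `CC(C)c1cccc(Nc2nc(Nc3ccc(N4CCN(C)CC4)cn3)ncc2Cl)c1` differs from compound 3 by 3-isopropylphenyl in place of 4-fluorobenzyl on a nitrogen on an aromatic ring. For the measured compounds named here, no measured step covers this change, so its size can only be guessed from what the set shows. Compound 2, which carries an aryl amino group at that nitrogen together with a piperazinyl aryl, gives 2060 nM in this assay. Compound 3 carries the benzyl amino group with a piperazinyl aryl and gives only a limit. Compound 1 also carries an aryl amino group and gives only a limit.

On this basis compound 4 is expected to move into the measurable range, the expected step being an at least 20-fold lower number from compound 3 to compound 4 (1.30 log units; beyond the scatter), though with wide uncertainty. Compound 4 is estimated at 5000 nM, expected between 800 nM and 60000 nM.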

Compound 4, concentration for 50% growth inhibition: 12300 nM
The estimate for compound 4 lay 2.5-fold (0.39 log units) below the measured number; the measured number falls inside the stated range.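

In this assay, among the compounds shown here, the change from (4-fluorobenzyl)amino to (3-isopropylphenyl)amino gives an at least 8.1-fold lower number from compound 3 to compound 4 (0.91 log units; beyond the scatter), the only step in the set that reads this nitrogen directly. With the rest of the structure held constant, the exchange at this one place is enough to bring the compound from the assay limit to a measurable value, whereas the earlier step concerned the aromatic carbon that carries the piperazine. The step remains a bound and its full size cannot be stated, because the value of compound 3 is only a limit of the assay: the limit of > 100000 nM in this assay, at which 2 of the 4 values shown sit.

The compounds shown do not separate the contributions of the parts that change together in this step: the carbon linking the ring to the nitrogen, the loss of fluorine and the arrival of isopropyl. They also leave open how the growth inhibition would respond to a plain phenyl, a 3-tert-butylphenyl, or a phenyl carrying an amine or a carboxylic acid on this nitrogen.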